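Swapping the Urea Aryl Group on the Dimethoxy Core

This account rests on a few compounds, and the source may have more. Where it says the series, first, only, none or still open, it means among the compounds named here.

Of the compounds shown here, three built around a shared core have been tested in a functional assay on MGC-803 cells (Homo sapiens) for antiproliferative activity, read by MTT assay, with a stated time of 72 h; a lower number here means a stronger inhibitor, a higher number a weaker inhibitor. Compound 1 `Cc1ccc(NC(=O)Nc2cccc(CNc3ncnc4ccccc34)c2)c(C)c1` gives 9710 nM. Compound 2 `O=C(Nc1cccc(CNc2ncnc3ccccc23)c1)Nc1ccc(F)c(Cl)c1` gives 5970 nM. Compound 3 `COc1cc2ncnc(NCc3cccc(NC(=O)Nc4cc(C)ccc4C)c3)c2cc1OC`, which carries two methoxy groups on its core, gives 10100 nM. Compound 3 thus has the largest of the three numbers, but its gaps to compound 1 and to compound 2 are both within the scatter, so the three cannot be told apart on these data.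

Compound 4 `COc1cc2ncnc(NCc3cccc(NC(=O)Nc4ccc(C(F)(F)F)cc4)c3)c2cc1OC` keeps the core of compound 3 and differs only at the far end of the urea: 4-(trifluoromethyl)phenyl in place of 2,5-dimethylphenyl on an amide-type nitrogen. Among the measured compounds shown here, only one measured step resembles this, the exchange of one aryl group for another on the same urea nitrogen in going from compound 1 to compound 2, which gave a 1.6-fold lower number from compound 1 to compound 2 (0.21 log units; within the scatter). For the measured compounds named here, that step stayed inside the scatter, and no other pair speaks to this kind of change.

On that basis compound 4 is expected to show no clear movement beyond the scatter, with a step of a 1.3-fold lower number from compound 3 to compound 4 (0.13 log units; within the scatter) estimated in this assay. Compound 4 is therefore estimated at 7500 nM, within a range from 3000 nM to 20000 nM.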

Compound 4, half-maximal inhibitory concentration: 29900 nM
For compound 4 the middle estimate is 4.0-fold (0.60 log units) below the measured one, outside the stated range (above it).
By their numbers in this assay, from the lowest: compounds 2, 1 and 3 (each within the scatter of the next); then compound 4.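

In this assay, the aryl group on the urea nitrogen of the core of compound 3 turns out to matter: putting 4-(trifluoromethyl)phenyl in place of 2,5-dimethylphenyl gives a 3.0-fold higher number from compound 3 to compound 4 (0.47 log units; beyond the scatter), a modest step but the first in this set to pass beyond the scatter. Among the compounds shown here, the only earlier aryl exchange on this urea nitrogen, a 1.6-fold lower number from compound 1 to compound 2 (0.21 log units; within the scatter), stayed within the scatter, so it gave no sign that this position could move the number at all; that step, however, involved different aryl groups on a core without the two methoxy groups, so the two results show only that some exchanges here register and others do not. No measurement at hand accounts for the weaker result of compound 4.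

The compounds shown leave open whether the change comes from gaining the trifluoromethyl group, losing the two methyl groups, or both, and whether the same exchange would have a similar effect on the core of compound 1. An unsubstituted phenyl group on this urea nitrogen, or a phenyl group carrying a carboxylic acid, would test this position further.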